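A Nitrile Enters the Benzamide Ring of Compound 1

A few compounds are considered here, and "the series" means these few. Any claim that something is new, unique, unknown or untested is made for them only; others in the source may bear on it.

Measured compounds:
compound 1 `O=C(Nc1cc(-c2ccccc2)nn1-c1ccccc1Br)c1ccccc1` with 200 nM
compound 2 `O=C(Nc1cc(-c2ccccc2)nn1-c1cccc(Br)c1)c1ccccc1` with 400 nM
compound 3 `COc1cccc(-n2nc(-c3ccccc3)cc2NC(=O)c2ccccc2)c1` with 570 nM

In a functional assay on cells for positive allosteric modulation of metabotropic glutamate receptor 5 (Rattus norvegicus), read by calcium flux (a higher number here means that more compound is needed for the effect, a lower number that less compound is needed), compound 1 gives 200 nM, the lowest of the three numbers. The step of a 2.0-fold higher number from compound 1 to compound 2 (0.30 log units; within the scatter) stays within the scatter, whereas the step of a 2.9-fold higher number from compound 1 to compound 3 (0.45 log units; beyond the scatter) is modest but beyond it, so compound 3 alone stands apart from compound 1. Between compound 2 and compound 3 the step of a 1.4-fold higher number from compound 2 to compound 3 (0.15 log units; within the scatter) is again within the scatter.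

Compound 4 `N#Cc1cccc(C(=O)Nc2cc(-c3ccccc3)nn2-c2ccccc2Br)c1` differs from compound 1 by cyano in place of hydrogen on an aromatic carbon, sitting on an aromatic carbon of a six-membered aromatic ring of carbon only, meta to a large group; read one bond further out, phenyl becomes 3-cyanophenyl. Within the data shown here, all three measured steps changed the aryl group on the aromatic nitrogen, and none touched the benzamide ring, so no measured step bears directly on this change. With nothing in the data pointing either way, the expected step of a 1.3-fold higher number from compound 1 to compound 4 (0.10 log units; within the scatter) is none beyond the scatter. Compound 4 is therefore estimated at 250 nM, within a range from 80 nM to 800 nM, in this assay.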

Compound 4, half-maximal effective concentration: 50 nM
Beside the measured number, compound 4's estimate is 5.0-fold (0.70 log units) above it; measured number below the stated range.
By their numbers in this assay, from the lowest: compound 4; then compounds 1, 2 and 3 (each within the scatter of the next, the first and the last beyond it).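

In this assay, among these compounds, the change from phenyl to 3-cyanophenyl gives a 4.0-fold lower number from compound 1 to compound 4 (0.60 log units; beyond the scatter) and so shows that the benzamide ring, which no earlier step touched, is not indifferent to substitution at this aromatic carbon, meta to a large group. The earlier steps all changed the aryl group on the aromatic nitrogen, and the only one beyond the scatter raised the number, whereas this addition of just 2 heavy atoms is the first change shown to lower it beyond the scatter, taking the series below compound 1, the lowest of the first three. No measurement offered here explains why the cyano group has this effect.

With a single substituent on this ring, the compounds leave open whether the drop belongs to the nitrile itself or would also follow from a chlorine atom, a methyl group, an amine or a carboxylic acid at the same place, or from the same group elsewhere on the ring. They also leave open whether the cyano group would lower the number to a similar extent on the 3-bromophenyl of compound 2 or the 3-methoxyphenyl of compound 3.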